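From a chloroaryl to a phenylethyl group at the ring amine

The compounds below may be only part of what the source reports. "The series", "measured", "known", "first", "only" and "open" are said of these compounds alone.

Compound 1 `CCCn1c(=O)c2[nH]c(-c3ccc(S(=O)(=O)N4CCN(c5ccc(Cl)cc5)CC4)cc3)nc2n(CC)c1=O` — in an assay on CHO cells for displacement of a labelled ligand from adenosine receptor A3 (Homo sapiens), read by scintillation counting, with a stated time of 45 min, in the presence of a further agent that is not named here (on this read-out lower numbers stand for stronger inhibition and higher numbers for weaker inhibition), compound 1 gives > 1000 nM, a limit of the assay.
Compound 2 `CCCn1c(=O)[nH]c2nc(-c3ccc(S(=O)(=O)N4CCN(c5ccccc5Cl)CC4)cc3)[nH]c2c1=O` — compound 2 gives > 1000 nM, likewise a limit.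

Compound 2 therefore stands at the limit of > 1000 nM in this assay, at which 2 of the 2 values shown sit, so no number is known for it. Compound 3 `CCCn1c(=O)[nH]c2nc(-c3ccc(S(=O)(=O)N4CCN(C(C)c5ccccc5)CC4)cc3)[nH]c2c1=O` differs from compound 2 by 1-phenylethyl in place of 2-chlorophenyl on an amine nitrogen in a ring. Among the measured compounds shown here, no step between measured compounds is available, so the direction of this change is open; a step beyond the usual scatter in either direction cannot be ruled out. Compound 3 is expected to give about 1500 nM, within 300 nM to 8000 nM. That estimate implies an expected step that the limit leaves unreadable from compound 2 to compound 3.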

Compound 3, inhibition constant: > 1000 nM
Compound 3 ended at the assay's limit; the forecaster's own chance of this, stated with the estimate: 60%; the middle value is on the limit's open side.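

No step can be read between compound 2 and compound 3, since each gives only a limit in this assay: the limit of > 1000 nM in this assay, at which 3 of the 3 values shown sit. Going by these compounds, whether 1-phenylethyl in place of 2-chlorophenyl strengthens or weakens inhibition, and by how much, stays open.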